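A few compounds are considered here, and "the series" means these few. Any claim that something is new, unique, unknown or untested is made for them only; others in the source may bear on it.

Compound 1, `CC(C)CCc1sc(NC(=O)c2cc(NC(=O)c3cc(NC(=N)c4cccc(F)c4)cn3C)cn2C)nc1C(=O)NCCCN(C)C`: 18 ug/mL
Compound 2, `CC(C)CCn1cc(NC(=O)c2cc(NC(=O)c3cc(NC(=N)c4ccccc4)cn3C)cn2C)cc1C(=O)NCCCN(C)C`: "not determined" (no result reported)

Among the compounds with values here, compound 1 is the only compound with a number in an ADME assay on HEK293 cells (Homo sapiens) for cytotoxicity, read by fluorescence and resazurin assay, with a stated time of 20 h; a higher number here means that more compound is tolerated, a lower number that less compound is tolerated. Compound 2 was run in this assay but for compound 2 the entry is "not determined" (no result reported), so nothing can be said about how the two compare. In this assay compound 1 gives 18 ug/mL, and that value stands alone as the sole reference point for everything that follows.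

Compound 3, `CC(C)CCc1sc(NC(=O)c2cc(NC(=O)c3cc(NC(=N)c4ccc(Cl)cc4)cn3C)cn2C)nc1C(=O)NCCCN(C)C`, is the compound still to be measured. It differs from compound 1 in a single place: 4-chlorophenyl in place of 3-fluorophenyl on a carbon with a double bond to nitrogen. In words, the change is 4-chlorophenyl in place of 3-fluorophenyl on a carbon with a double bond to nitrogen, while the shared core is left untouched. Within the data shown here, no pair of measured compounds shows what such a swap of one halogen-bearing phenyl ring for another does in this assay, so the expectation rests on compound 1 alone. The expected step of a 1.2-fold lower number from compound 1 to compound 3 (0.08 log units; within the scatter) is small, within the usual scatter, with no settled direction. Compound 3 is therefore estimated to give 15 ug/mL, with a range from 7 ug/mL to 35 ug/mL.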

Compound 3, half-maximal cytotoxic concentration: 10 ug/mL
For compound 3 the middle estimate is 1.5-fold (0.18 log units) above the measured one; measured number inside the range.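

In this assay, within the data shown here, putting 4-chlorophenyl in place of 3-fluorophenyl on the carbon with a double bond to nitrogen gives a 1.8-fold lower number from compound 1 to compound 3 (0.26 log units; within the scatter), the first measured step at this position. The step lies within the usual scatter of repeated measurements, so this pair does not separate the two compounds, even though the halogen and its place on the ring both differ. No measured evidence bearing on this result is available, so the number describes the outcome of the swap without explaining it.

Since the halogen and its ring position change together, this single pair cannot show what either change would do alone. It also leaves open whether the tolerated concentration would stay in the same range with a different kind of group at this position, such as a ring carrying an amine or a carboxylic acid, or a longer chain in place of the ring.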